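The source may hold more compounds than are shown below. What is called first, only, known or untested is meant among the compounds shown, and "the series" means these compounds.

Of the compounds shown here, two have so far been tested in a functional assay on MT4 cells (Homo sapiens) for cytotoxicity, read by MTT assay; on this read-out higher numbers stand for lower toxicity in this test and lower numbers for higher toxicity in this test: compound 1 (`Cc1c(O)nc(SCc2ccc(C#N)cc2)nc1Cc1c(Cl)cccc1Cl`) and compound 2 (`Cc1c(O)nc(SCc2cccc(C#N)c2)nc1Cc1c(Cl)cccc1Cl`). Compound 1 gives > 60000 nM, which is a limit of the assay and not a number. Compound 2 gives > 60000 nM, which is likewise a limit, so its place on the scale cannot be fixed any more closely. The next compound is compound 3 (`Cc1c(O)nc(SCc2ccc(F)cc2)nc1Cc1c(Cl)cccc1Cl`), with 4-fluorophenyl in place of 3-cyanophenyl on a saturated chain carbon bound to a sulfur. Within the data shown here, the only measured step at this place, with 3-cyanophenyl in place of 4-cyanophenyl, is a step that the two limits leave unreadable from compound 1 to compound 2. It offers no size to carry over, and all that the data show is the limit of > 60000 nM in this assay, at which 2 of the 2 values shown sit. No step beyond the usual scatter is therefore expected in this assay, and no direction can be favoured. The expected outcome is an at least 1.0-fold lower number from compound 2 to compound 3 (0.03 log units; that floor lies within the scatter). For compound 3 the half-maximal cytotoxic concentration is estimated at 55000 nM, with an expected range from 15000 nM to 100000 nM.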

Compound 3, half-maximal cytotoxic concentration: > 61000 nM
Compound 3 gave a limit, no number (the forecaster's own chance of this, stated with the estimate: 70%); middle value at least 1.1-fold (0.04 log units) away from the limit.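

In this assay, compound 1, compound 2 and compound 3 each give only a limit of the assay and not a number, so no step among these three compounds can be read. The compounds shown leave open whether 4-cyanophenyl, 3-cyanophenyl and 4-fluorophenyl on this saturated chain carbon differ at all in this assay, and at what concentration each compound would reach its half-maximal cytotoxic effect.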